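The source may hold more compounds than are shown below. What is called first, only, known or untested is meant among the compounds shown, and "the series" means these compounds.

Compound 1, `c1ccc(Cc2[nH]cnc3ncnc2-3)cc1`, in an assay on isolated protein for inhibition of RAC-alpha serine/threonine-protein kinase (Homo sapiens), tested at 30 uM (on this read-out higher numbers stand for more inhibition at the one concentration tested (going by the name of the read-out) and lower numbers for less inhibition), gives 0%.
Compound 2, `Fc1ccc(Cc2[nH]cnc3ncnc2-3)cc1`, gives 3%.
Compound 3, `Cn1c(-c2ccc(S(C)(=O)=O)cc2)nc2c(Sc3ccccc3)ncnc21`, gives 14%.

Compound 3 stands highest of the three; its number lies beyond the scatter above both compound 2 and compound 1. The difference between the core of compound 1 and the core of compound 3 is not broken down here.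

One structural change appears twice among these compounds. From compound 1 to compound 2 it is fluoro in place of hydrogen on an aromatic carbon, and it made a number 3 percentage points higher from compound 1 to compound 2 (within the scatter). Compound 4, `Cn1c(-c2ccc(S(C)(=O)=O)cc2)nc2c(Sc3ccc(F)cc3)ncnc21`, differs from compound 3 by fluoro in place of hydrogen on an aromatic carbon. The place is described in the same words for both pairs, so this is the same change.

Because the earlier step was a number 3 percentage points higher from compound 1 to compound 2 (within the scatter), only a small step is expected from compound 3 to compound 4, namely a number 3 percentage points higher from compound 3 to compound 4 (within the scatter). Compound 4 is therefore estimated at 17%, likely between 5% and 32%.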

Compound 4, a percentage reported as inhibition, at one concentration (the size of the read-out at that concentration, not a potency): 4%
Estimate against measurement, compound 4: 13 percentage points above; the measured number lies below the stated range.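

In this assay, fluoro in place of hydrogen gave a number 10 percentage points lower from compound 3 to compound 4 (within the scatter). Set beside the earlier step, the change shows no difference between the two cores beyond what repeated measurement allows: the same change on two cores in this assay, a number 3 percentage points higher (within the scatter) from compound 1 to compound 2 and a number 10 percentage points lower (within the scatter) from compound 3 to compound 4, 13 percentage points apart, within the scatter of two such steps. This shows that the step stayed within the scatter on both cores, but it does not show that the change carries over with a fixed size or direction.

The compounds shown leave open whether another group at that place, such as an amine or a carboxylic acid, would move the number beyond the scatter on either core. They also leave open which part of the core of compound 3 sets it apart from compound 1 and compound 2.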